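The source may report more compounds than this note shows. Statements on the series, on what has been measured and on what is new or still open speak of the compounds shown alone.

Compound 1 `N#CC1=C(N)Oc2c(c3nc4ccccc4nc3c3ccccc23)C12C(=O)N(Cc1cnnn1-c1cc(Cl)ccc1Cl)c1ccccc12` and compound 2 `N#CC1=C(N)Oc2c(N)cc3nc4ccccc4nc3c2C12C(=O)N(Cc1cnnn1-c1ccc(F)cc1)c1ccccc12` share the same core and were both tested in a functional assay on HepG2 cells (Homo sapiens) for antiproliferative activity, read by MTT assay, with a stated time of 48 h; on this read-out higher numbers stand for weaker inhibition and lower numbers for stronger inhibition. In this assay compound 1 reaches only the limit of the assay, > 50000 nM, not a number. Compound 2 likewise stops at the limit, > 50000 nM, with no number behind it. Where compound 2 stands is given only by the limit of > 50000 nM in this assay, at which 2 of the 2 values shown sit; on the numbers shown it is not separated from compound 1. Compound 3 `Cc1cc(C)cc(-n2nncc2CN2C(=O)C3(C(C#N)=C(N)Oc4c(N)cc5nc6ccccc6nc5c43)c3ccccc32)c1` has not been measured. It differs from compound 2 in one place: 3,5-dimethylphenyl in place of 4-fluorophenyl on an aromatic nitrogen, the 3,5-dimethylphenyl entering on the aromatic nitrogen of the five-membered aromatic ring with 3 nitrogen where the 4-fluorophenyl leaves. Going by the values given here, no measured pair shows what such a change does in this assay. The step from compound 2 to compound 3 is expected to be small, a step that the limit leaves unreadable from compound 2 to compound 3. Compound 3 is expected to give about 60000 nM in this assay, between 20000 nM and 200000 nM, most likely again only as a limit.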

Compound 3, half-maximal inhibitory concentration: > 50000 nM
Compound 3: only a limit was reported; the forecaster's own chance of this, stated with the estimate: 80%; the middle value lies beyond the limit too.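

No step can be read between compound 2 and compound 3, because in this assay both stop at a limit and not at a number: the limit of > 50000 nM in this assay, at which 3 of the 3 values shown sit. The compounds shown leave open what any change on the shared core does to a measurable value in this assay.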